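A few compounds are considered here, and "the series" means these few. Any claim that something is new, unique, unknown or untested is made for them only; others in the source may bear on it.

Of the compounds shown here, three built on one shared core have been measured in an assay on HEK293-A cells for agonist activity at probable G-protein coupled receptor 34 (Mus musculus), with a stated time of 1.5 h; on this read-out lower numbers stand for smaller maximal responses and higher numbers for larger maximal responses. Compound 1 `N[C@@H](COP(=O)(O)O[C@@H]1CCCO[C@@H]1COC(=O)CCc1ccccc1OCc1cccc(Oc2ccccc2)c1)C(=O)O` gives 14.8% in this assay. Compound 2 `N[C@@H](COP(=O)(O)OC[C@H]1OCCC[C@@H]1OC(=O)CCc1ccccc1OCc1cccc(Oc2ccccc2)c1)C(=O)O` is reported as "not active" (no number reported) in this assay, without a number. Compound 3 `CCCCCCCC/C=C\CCCCCCCC(=O)O[C@H]1CCCO[C@@H]1COP(=O)(O)OC[C@H](N)C(=O)O` is likewise reported as "not active" (no number reported) in this assay. Compound 2 thus stands among the two compounds for which no single number is known, and only compound 1 carries a numbered response. Compound 4 `N[C@@H](COP(=O)(O)OC[C@H]1OCCC[C@H]1OC(=O)CCc1ccccc1OCc1cccc(Oc2ccccc2)c1)C(=O)O` has not yet been measured. It differs from compound 2 in a single point: the two compounds have the same atoms and bonds; at least one stereo element is drawn with a configuration in one of them and without one in the other: 1 of 4 stereo elements differ; a stereocentre at a saturated ring carbon is drawn S in compound 2 and R in compound 4. Among the compounds with values here, no measured pair shows what such a change does here, so only a small effect is expected, not one clearly beyond the usual scatter, and a low response remains the most likely outcome. Compound 4 is expected to give about 10% in this assay, between 0% and 30%.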

Compound 4, largest response reached (Emax), in percent of the reference or control that the assay uses: 17.7%
Beside the measured number, compound 4's estimate is 7.7 percentage points below it; low and high end bracket the measured number.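

Compound 4 gives 17.7%, but compound 2 is reported without a number, so no step can be read between them. From the compounds shown here alone, how far the swap from S to R at that saturated ring carbon shifts the response remains open.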